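The source may hold more compounds than are shown below. What is called first, only, known or untested is meant among the compounds shown, and "the series" means these compounds.

In a functional assay on PC-3 cells (Homo sapiens) for antiproliferative activity, read by MTT assay, with a stated time of 24 h (a higher number here means a weaker inhibitor, a lower number a stronger inhibitor), two amides sharing one core have been measured so far. Compound 1 `CCn1c(C(=O)N[C@@H](CO)C(C)C)ccc1C(CC)(CC)c1ccc(OCS(=O)(=O)c2ccccc2)c(C)c1` gives 10600 nM, and compound 2 `CCn1c(C(=O)N[C@@H](CO)CCO)ccc1C(CC)(CC)c1ccc(OCS(=O)(=O)c2ccccc2)c(C)c1` gives 14100 nM. These two values lie within the scatter of each other, so the numbers do not separate compound 2 from compound 1.

Compound 3 `CCn1c(C(=O)N[C@H](CO)CCCO)ccc1C(CC)(CC)c1ccc(OCS(=O)(=O)c2ccccc2)c(C)c1` has not yet been measured. It differs from compound 2 on the amide-type nitrogen: a group of 7 heavy atoms (5 carbon, 2 oxygen; no ring) in place of a group of 6 heavy atoms (4 carbon, 2 oxygen; no ring), on an amide-type nitrogen. Among the compounds with values here, only one measured step bears on this change, as it also alters the group on that nitrogen. With 2-hydroxyethyl in place of isopropyl, it is a 1.3-fold higher number from compound 1 to compound 2 (0.12 log units; within the scatter). One small step is thin evidence, but no step beyond the scatter is expected in this assay. The expected step is a 1.1-fold lower number from compound 2 to compound 3 (0.04 log units; within the scatter). For compound 3, the estimated value is 13000 nM, with an expected range from 6500 nM to 26000 nM.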

Compound 3, half-maximal inhibitory concentration: 6810 nM
Compound 3: the middle estimate sits 1.9-fold (0.28 log units) above what was measured, within the range that was stated.
By their numbers in this assay, from the lowest: compounds 3, 1 and 2 (each within the scatter of the next, the first and the last beyond it).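

In this assay, the group on the amide-type nitrogen can now be seen to shift the number beyond the scatter: the group of 7 heavy atoms, in place of 3-hydroxy-1-(hydroxymethyl)propyl, gives a 2.1-fold lower number from compound 2 to compound 3 (0.32 log units; beyond the scatter), a modest step, although both groups hold the same count of hydrogen-bond donors and acceptors. A second step stays within the scatter, a 1.6-fold lower number from compound 1 to compound 3 (0.19 log units; within the scatter), so the new group does not stand apart from every group on this nitrogen. No measurement shown here accounts for the step.

Still open, as far as these compounds go, is whether a longer hydroxyalkyl chain on this nitrogen would shift the number further, or whether an amine or a carboxylic acid in place of a hydroxyl would keep the step. The mirror-image form of the defined stereocentre also remains an open question.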